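Bulkier sulfanyl group on the acylguanidine core

The source may hold more compounds than are shown below. What is called first, only, known or untested is meant among the compounds shown, and "the series" means these compounds.

Measured so far:
compound 1 `Cc1cc(C)c(S(C)(=O)=O)cc1C(=O)N=C(N)N`: 11 nM
compound 2 `CCCCCc1cc(C)c(C(=O)N=C(N)N)cc1S(C)(=O)=O`: 27 nM
compound 3 `CSc1cc(C)c(C(=O)N=C(N)N)cc1S(C)(=O)=O`: 6 nM

In a functional assay for inhibition of sodium/hydrogen exchanger (Oryctolagus cuniculus) (a lower number here means a stronger inhibitor, a higher number a weaker inhibitor), compound 1 gives 11 nM, the second highest of the three numbers; compound 3 stands nearest to it, compound 2 furthest. The step to compound 4 `Cc1cc(SC(C)(C)C)c(S(C)(=O)=O)cc1C(=O)N=C(N)N` is (tert-butyl)sulfanyl in place of methyl on an aromatic carbon, on an aromatic carbon ortho to a methylsulfonyl group, meta to a methyl group and para to a group of 6 heavy atoms. For the measured compounds named here, two measured steps bear on it. The step of a 1.8-fold lower number from compound 1 to compound 3 (0.26 log units; within the scatter) shows that a sulfanyl group in place of methyl at this carbon changes little. The step of a 2.5-fold higher number from compound 1 to compound 2 (0.39 log units; beyond the scatter) shows that lengthening the chain at this carbon weakens inhibition modestly, and the step of a 4.5-fold lower number from compound 2 to compound 3 (0.65 log units; beyond the scatter) points the same way. Compound 4 combines a sulfanyl group with a larger carbon group, so a small step upward or none beyond the scatter is expected in this assay, roughly a 1.3-fold higher number from compound 1 to compound 4 (0.10 log units; within the scatter). For compound 4 the expected value is 14 nM, between 5 nM and 40 nM.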

Compound 4, half-maximal inhibitory concentration: 22 nM
Estimate against measurement, compound 4: 1.6-fold (0.20 log units) below; low and high end bracket the measured number.
By their numbers in this assay, from the lowest: compounds 3, 1, 4 and 2 (each within the scatter of the next, the first and the last beyond it).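

In this assay, for the compounds shown here, the one change made on the sulfur itself, tert-butyl in place of methyl, gives a 3.7-fold higher number from compound 3 to compound 4 (0.56 log units; beyond the scatter) and so shows that the group carried on this sulfur matters, which the earlier compounds could not show. At the aromatic carbon, (tert-butyl)sulfanyl in place of methyl gives a 2.0-fold higher number from compound 1 to compound 4 (0.30 log units; within the scatter) and in place of pentyl gives a 1.2-fold lower number from compound 2 to compound 4 (0.09 log units; within the scatter) so this bulky sulfanyl group cannot be told apart from either carbon group at this position. Nothing at hand explains the step on the sulfur.

The compounds shown leave open whether that step follows the number of carbons on the sulfur or their branching, which an ethylsulfanyl or an unbranched butylsulfanyl group would address. As far as these compounds go, how an amine or a phenoxy group at this carbon would read in this assay also stays open.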